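A few compounds are considered here, and "the series" means these few. Any claim that something is new, unique, unknown or untested is made for them only; others in the source may bear on it.

For the measured compounds named here, compound 1 `CCn1c(C(=O)NCCN)ccc1C(CC)(CC)c1ccc(OCS(=O)(=O)c2ccccc2)c(C)c1` is one of two compounds measured so far in a functional assay on PC-3 cells (Homo sapiens) for antiproliferative activity, read by MTT assay, with a stated time of 24 h (on this read-out lower numbers stand for stronger inhibition and higher numbers for weaker inhibition), where compound 1 gives 6890 nM. Its companion, compound 2 `CCn1c(C(=O)N[C@H](CO)C(C)C)ccc1C(CC)(CC)c1ccc(OCS(=O)(=O)c2ccccc2)c(C)c1`, carries 1-(hydroxymethyl)-2-methylpropyl on the amide-type nitrogen; in this assay compound 2 gives 7300 nM. The step of a 1.1-fold higher number from compound 1 to compound 2 (0.03 log units; within the scatter) shows that exchanging the 2-aminoethyl group for this substituent left the number essentially unchanged, and compound 1 holds the lowest of the two numbers only by a margin within the scatter.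

Compound 3 `CCn1c(C(=O)N[C@H](CCC(=O)O)C(=O)O)ccc1C(CC)(CC)c1ccc(OCS(=O)(=O)c2ccccc2)c(C)c1` has not yet been measured. It differs from compound 1 in one place: 1,3-dicarboxypropyl in place of 2-aminoethyl on an amide-type nitrogen. Going by the values given here, the only measured step that bears on this position, from compound 1 to compound 2, was within the scatter, so the amide-type nitrogen appears to accept different substituents with little effect on the read-out, at least across the two cases seen. On that basis the expected change in this assay is small, a 1.3-fold higher number from compound 1 to compound 3 (0.12 log units; within the scatter), with no direction supported beyond the scatter. Compound 3 is therefore estimated at 9000 nM, expected to lie between 4000 nM and 25000 nM.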

Compound 3, half-maximal inhibitory concentration: > 50000 nM
Compound 3 ended at the assay's limit; the forecaster's own chance of this, stated with the estimate: 20%; middle value at least 5.5-fold (0.74 log units) away from the limit.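

The amide-type nitrogen proved less tolerant than the first pair suggested, since 1,3-dicarboxypropyl on this nitrogen gives an at least 7.2-fold higher number from compound 1 to compound 3 (0.86 log units; beyond the scatter) and, against the other earlier substituent, an at least 6.8-fold higher number from compound 2 to compound 3 (0.83 log units; beyond the scatter). The earlier exchange of 2-aminoethyl for 1-(hydroxymethyl)-2-methylpropyl gave only a 1.1-fold higher number from compound 1 to compound 2 (0.03 log units; within the scatter), so the read-out at this position does depend on the substituent, and not every change here is silent. In this assay compound 3 stands at a limit of the assay and not at a number, so both new steps give only the least size of the change: the limit of > 50000 nM in this assay, at which 1 of the 3 values shown sits.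

The three compounds do not show which feature of the 1,3-dicarboxypropyl group goes with this loss, as its two carboxylic acids and its longer chain enter together. Going by these compounds, it remains open whether a single carboxylic acid on a short chain, such as carboxymethyl, would move the number as far, and whether the dimethyl ester of the same group would keep it near the values of the two earlier compounds.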